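Compound 3: swapping 3-hydroxypropyl for 2-methoxyethyl

The source may report more compounds than this note shows. Statements on the series, on what has been measured and on what is new or still open speak of the compounds shown alone.

Compound 1 `COCCCN1C(/C=C/c2ccc(O)cc2)=CC(=O)CC1c1ccc(O)cc1`: 25800 nM
Compound 2 `O=C(/C=C(/C=C/c1ccc(O)cc1)NCCCO)/C=C/c1ccc(O)cc1`: 137000 nM
Compound 3 `COCCNC(=C\C(=O)/C=C/c1ccc(O)cc1)/C=C/c1ccc(O)cc1`: not yet measured

In a physicochemical assay for solubility, using the shake flask method, in phosphate buffer, with a stated time of 90 min, at pH 6.8 (on this read-out higher numbers stand for higher solubility and lower numbers for lower solubility), compound 2 gives 137000 nM, the higher of the two numbers, and its gap to compound 1 lies beyond the usual scatter. Compound 3 has the same atoms as compound 2, joined differently: methoxy in place of hydroxymethyl on a saturated chain carbon, two bonds along the chain from an amine nitrogen. This places methoxy in place of hydroxymethyl on a saturated chain carbon, two bonds along the chain from an amine nitrogen, so that 3-hydroxypropyl becomes 2-methoxyethyl.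

Going by the values given here, no measured pair differs in one place only, so the size of this change has no direct precedent. A small downward step is expected, a 1.7-fold lower number from compound 2 to compound 3 (0.23 log units; within the scatter), and it is not expected to clear the scatter. The direction rests only weakly on compound 1, which carries a methoxy and gives 25800 nM, since the core of compound 1 differs from that of compound 2. For compound 3 the estimated value in this assay is 80000 nM, with an expected range of 30000 nM to 200000 nM.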

Compound 3, solubility: 37500 nM
The estimate for compound 3 lay 2.1-fold (0.33 log units) above the measured number, within the range that was stated.
By their numbers in this assay, from the lowest: compounds 1 and 3 (each within the scatter of the next); then compound 2.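

Position note: on a saturated chain carbon, two bonds along the chain from an amine nitrogen, this assay gives the series its first pair differing in one place, and the change of 3-hydroxypropyl to 2-methoxyethyl reads as a 3.7-fold lower number from compound 2 to compound 3 (0.56 log units; beyond the scatter). This position is therefore not silent: a swap that keeps the atoms the same, with hydroxymethyl (1 hydrogen-bond donor) leaving and methoxy (0 hydrogen-bond donors) entering, is accompanied by a step that clears the scatter, though only a modest one. Nothing measured in this set bears on what lies behind the step.

Going by these compounds alone, still open is which part of the swap carries the step, since the single pair alters the chain and its end group together, and 2-hydroxyethyl or 3-methoxypropyl on the core shared by compound 2 and compound 3 would separate the two. Also open, from the compounds shown here alone, is how an amine, a carboxylic acid or a longer chain at this place would read in this assay, as one pair gives a single direction and no trend.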